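The source may report more compounds than this note shows. Statements on the series, on what has been measured and on what is new or still open speak of the compounds shown alone.

Measured so far:
compound 1 `Cc1ccc(Nc2nc(Cl)nc3c2ncn3Cc2ccc(C(=O)Nc3ccccc3N)cc2)cc1`: 67.3%
compound 2 `CCCCn1cnc2c(NCc3ccc(C(=O)Nc4ccccc4N)cc3)nc(Cl)nc21`: 19.7%
compound 3 `Nc1ccccc1NC(=O)c1ccc(COCNc2nc(Nc3cccc(Cl)c3)c3ncn(C4CCCC4)c3n2)cc1`: 36.1%

All three numbers come from a functional assay on NCI-H460 cells (Homo sapiens) for antiproliferative activity, read by CCK-8 assay, with a stated time of 72 h, tested at 2 uM; on this read-out higher numbers stand for a stronger effect at the one concentration tested and lower numbers for a weaker effect. Among them compound 2 gives the lowest number; the nearest is compound 3, whose number lies higher by a gap beyond the scatter, and the furthest is compound 1, higher by a gap also beyond the scatter. For the measured compounds named here, no pair here differs in a single place, so only the bare numbers can be compared.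

The next compound, compound 4 `CCCn1cnc2c(NCc3ccc(C(=O)Nc4ccccc4N)cc3)nc(Cl)nc21`, differs from compound 2 in one place: hydrogen in place of methyl on a saturated chain carbon, three bonds along the chain from an aromatic nitrogen. With nothing measured for such a chain shortening in this series, the step in this assay is expected to be small, in no settled direction, and not beyond the scatter. The step from compound 2 to compound 4 is estimated as a number 1.3 percentage points higher from compound 2 to compound 4 (within the scatter). Compound 4 is therefore expected near 21%, within a range of 8% to 36%.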

Compound 4, a percentage reported as inhibition, at one concentration (the size of the read-out at that concentration, not a potency): 31%
The estimate for compound 4 lay 10 percentage points below the measured number; measured number inside the range.
By their numbers in this assay, from the lowest: compound 2; then compounds 4 and 3 (each within the scatter of the next); then compound 1.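

In this assay, hydrogen in place of methyl on a saturated chain carbon, three bonds along the chain from an aromatic nitrogen, the change from butyl to propyl, gives a number 11.3 percentage points higher from compound 2 to compound 4 (beyond the scatter). For the compounds shown here, this is the first single-place comparison, and it shows that this chain end alone can move the read-out by a modest step. Nothing available accounts for the step.

As far as these compounds go, whether ethyl or methyl would extend this step remains open. So does the effect of a longer chain, such as pentyl, or of a terminal amine.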